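Swapping piperidin-1-yl for morpholin-4-yl on a sulfonyl sulfur

This account rests on a few compounds, and the source may have more. Where it says the series, first, only, none or still open, it means among the compounds named here.

- compound 1 `O=C(Nc1sccc1C(=O)Nc1ccccn1)c1ccc(S(=O)(=O)N2CCCCC2)cc1` gives "nd" (no result reported)
- compound 2 `Cc1ccnc(NC(=O)c2ccsc2NC(=O)c2ccc(S(=O)(=O)N3CCCCC3)cc2)n1` gives 32.8 ug/mL

Knowing how much of a compound harms cells is a basic early check, and here the evidence comes from a toxicity assay on Vero cells (Chlorocebus sabaeus) for cytotoxicity, read by MTT assay; a lower number here means a stronger inhibitor, a higher number a weaker inhibitor. The data are thin. Compound 1 has no number ("nd" (no result reported)), so compound 2 (32.8 ug/mL) stands alone, with nothing to rank it against.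

Compound 3 `Cc1ccnc(NC(=O)c2ccsc2NC(=O)c2ccc(S(=O)(=O)N3CCOCC3)cc2)n1` differs from compound 2 in one group only: morpholin-4-yl in place of piperidin-1-yl on a sulfonyl sulfur. In words, morpholin-4-yl takes the place of piperidin-1-yl on a sulfonyl sulfur, and the rest of the molecule stays the same.

Going by the values given here, no measured pair shows what this swap does, so the size of the step has to be a cautious guess. Among the compounds with values here, since only one group changes, a small shift is expected. The estimated 1.2-fold higher number from compound 2 to compound 3 (0.09 log units; within the scatter) leans slightly towards a weaker inhibitor and is expected to stay within the usual scatter of repeated measurements. The estimate for compound 3 is 40 ug/mL in this assay, with 15 ug/mL to 100 ug/mL as the expected range.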

Compound 3, half-maximal inhibitory concentration: 42.7 ug/mL
The estimate for compound 3 lay 1.1-fold (0.03 log units) below the measured number, and the stated range covers the measured number.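

In this assay, going by these compounds alone, the swap of piperidin-1-yl for morpholin-4-yl on a sulfonyl sulfur gives the first readable step at this position (a 1.3-fold higher number from compound 2 to compound 3 (0.11 log units; within the scatter)), and that step lies within the usual scatter of repeated measurements, so compound 2 and compound 3 cannot be told apart in this test. The swap is a real change in the group: an oxygen enters the ring, and the count of hydrogen-bond acceptors on the group goes from 0 to 1, while the ring size and the number of heavy atoms stay the same. Even so, that change leaves no readable mark on this cell toxicity result, and nothing measured here offers an explanation for the outcome.

Both compounds carry a six-membered non-aromatic ring on the sulfonyl sulfur, so the compounds shown leave open what an open-chain group such as dimethylamino, or a ring with a second nitrogen such as piperazin-1-yl, would do in that place. One step on one core also leaves open whether the same swap would read the same way with a different group at the other end of the molecule.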